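A ring gives way to a chain in compound 4

A few compounds are considered here, and "the series" means these few. Any claim that something is new, unique, unknown or untested is made for them only; others in the source may bear on it.

Of the compounds shown here, three have been tested in a functional assay on PC-3 cells (Homo sapiens) for inhibition, read by sulforhodamine B assay, with a stated time of 48 h; on this read-out lower numbers stand for stronger inhibition and higher numbers for weaker inhibition. Compound 1 `O=C(Nc1ccc2c(c1)CCCN2Cc1ccc(C(=O)NO)cc1)Nc1ccc(Cl)c(C(F)(F)F)c1` gives 3200 nM. Compound 2 `O=C(/C=C/c1ccc(NC(=O)Nc2ccc(Cl)c(C(F)(F)F)c2)cc1)NO` gives 1900 nM, and these two values lie within the usual scatter of each other. Compound 3 `O=C(Nc1ccc(Nc2ncc(C(=O)NO)cn2)cc1)Nc1ccc(Cl)c(C(F)(F)F)c1` returns no number, only a limit of > 10000 nM. Its place in the series is therefore (the limit of > 10000 nM in this assay, at which 1 of the 3 values shown sits).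

Compound 4 `O=C(CCCCCC(=O)Nc1ccc(NC(=O)Nc2ccc(Cl)c(C(F)(F)F)c2)cc1)NO` differs from compound 3 by having (5-(hydroxycarbamoyl)pentyl)carbonyl in place of 5-(hydroxycarbamoyl)pyrimidin-2-yl on a nitrogen on an aromatic ring. Among the measured compounds shown here, no measured pair shows this kind of change directly, so the expectation rests on the two numbers available, compound 1 at 3200 nM and compound 2 at 1900 nM. Compound 4 is expected to fall near them in this assay, with stronger inhibition than the limit reached so far. The expected step is an at least 3.3-fold lower number from compound 3 to compound 4 (0.52 log units; beyond the scatter), a shift beyond the scatter. For compound 4 the estimated value is 3000 nM, with an expected range from 900 nM to 10000 nM.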

Compound 4, half-maximal inhibitory concentration: > 10000 nM
Compound 4: only a limit was reported; the forecaster's own chance of this, stated with the estimate: 15%; at least 3.3-fold (0.52 log units) between middle value and limit.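

Compound 3 and compound 4 each give only a limit, not a number, so the step between them cannot be read: the limit of > 10000 nM in this assay, at which 2 of the 4 values shown sit.

The compounds shown leave open whether (5-(hydroxycarbamoyl)pentyl)carbonyl or 5-(hydroxycarbamoyl)pyrimidin-2-yl on a nitrogen on an aromatic ring gives stronger inhibition in this assay.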